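Three aryl amides, one shared core, and a trifluoromethyl question

A few compounds are considered here, and "the series" means these few. Any claim that something is new, unique, unknown or untested is made for them only; others in the source may bear on it.

Measured so far in a functional assay on 143B cells (Homo sapiens) for inhibition, read by MTT assay, with a stated time of 72 h; a higher number here means a weaker inhibitor, a lower number a stronger inhibitor:
- compound 1, `O=C(CCC(=O)OCCCCCCSc1ccc([N+](=O)[O-])c2nonc12)Nc1ccccc1Cl`: 2430 nM
- compound 2, `O=C(CCC(=O)OCCCCCCSc1ccc([N+](=O)[O-])c2nonc12)Nc1cccc(Cl)c1`: 2890 nM
- compound 3, `COc1ccc(NC(=O)CCC(=O)OCCCCCCSc2ccc([N+](=O)[O-])c3nonc23)cc1`: 3060 nM

All three compounds share the same core and differ only in the aryl group on the amide-type nitrogen. Compound 1 sits at the low end of the three numbers, yet the steps to the others are small: a 1.2-fold higher number from compound 1 to compound 2 (0.08 log units; within the scatter), a 1.3-fold higher number from compound 1 to compound 3 (0.10 log units; within the scatter), and a 1.1-fold higher number from compound 2 to compound 3 (0.02 log units; within the scatter). None of them rises above the usual scatter, so the three aryl groups seen so far cannot be told apart in this assay.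

Compound 4, `O=C(CCC(=O)OCCCCCCSc1ccc([N+](=O)[O-])c2nonc12)Nc1ccc(C(F)(F)F)cc1`, carries another aryl group. The change from compound 1 is 4-(trifluoromethyl)phenyl in place of 2-chlorophenyl on an amide-type nitrogen.

Among the measured compounds shown here, the steps that bear on this are the three aryl swaps already measured, each within the scatter. For the measured compounds named here, there is no measured step for a trifluoromethyl group, so the expectation rests only on the flatness of those swaps. No step beyond the scatter is expected for compound 4, which is estimated at 2700 nM, between 1200 nM and 6000 nM. The expected change from compound 1 is a 1.1-fold higher number from compound 1 to compound 4 (0.05 log units; within the scatter).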

Compound 4, half-maximal inhibitory concentration: 2100 nM
Estimate against measurement, compound 4: 1.3-fold (0.11 log units) above, within the range that was stated.
By their numbers in this assay, from the lowest: compounds 4, 1, 2 and 3 (each within the scatter of the next).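

In this assay, among the compounds shown here, a swap to a larger aryl group, with 10 heavy atoms in place of 7, still gives no step that can be told from the scatter (against the 2-chlorophenyl amide, a 1.2-fold lower number from compound 1 to compound 4 (0.06 log units; within the scatter); against the 3-chlorophenyl amide, a 1.4-fold lower number from compound 2 to compound 4 (0.14 log units; within the scatter)). The direct exchange of methoxy for trifluoromethyl on the aromatic carbon also stays within the scatter (a 1.5-fold lower number from compound 3 to compound 4 (0.16 log units; within the scatter)), so all four aryl groups on the amide-type nitrogen remain indistinguishable here. Nothing measured explains why these numbers stay so close.

The compounds shown leave open what a carboxylic acid or an amine on the aryl ring would do, or a simple methyl in place of the whole ring. They also say nothing about changes elsewhere, such as a longer chain in the shared core.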